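From Hydroxy to Isopropyl in a Level Series

A few compounds are considered here, and "the series" means these few. Any claim that something is new, unique, unknown or untested is made for them only; others in the source may bear on it.

The series opens with compound 1 `COc1cc(/C=N/c2c(C#N)ncn2-c2ccc(F)cc2)ccc1O` and compound 2 `N#Cc1ncn(-c2ccc(F)cc2)c1/N=C/c1ccc(O)cc1` and compound 3 `COc1ccc(/C=N/c2c(C#N)ncn2-c2ccc(F)cc2)cc1O` which all share one core. In a functional assay on T47D cells (Homo sapiens) for antiproliferative activity, read by MTT assay, with a stated time of 48 h (on this read-out higher numbers stand for weaker inhibition and lower numbers for stronger inhibition), compound 1 gives 20100 nM while compound 2 gives 20400 nM and compound 3 gives 20000 nM so compound 2 stands level with the other two, within the scatter.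

The next structure is compound 4 `CC(C)c1ccc(/C=N/c2c(C#N)ncn2-c2ccc(F)cc2)cc1` which differs from compound 2 by isopropyl in place of hydroxy on an aromatic carbon with isopropyl in place of hydroxy on an aromatic carbon. For the measured compounds named here, one measured step bears on this change, the replacement of methoxy by hydrogen on an aromatic carbon, and it is small: a 1.0-fold higher number from compound 1 to compound 2 (0.01 log units; within the scatter) and so within the scatter. Going by the values given here, no measured compound carries isopropyl, so that step is only weak guidance. No step beyond the scatter is therefore expected in this assay for this change. The expected step is a 1.3-fold lower number from compound 2 to compound 4 (0.11 log units; within the scatter) and it stays within the scatter. For compound 4 the estimated value is 16000 nM with an expected range from 6000 nM to 40000 nM in this assay.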

Compound 4, half-maximal inhibitory concentration: > 25000 nM
Compound 4 ended at the assay's limit; the forecaster's own chance of this, stated with the estimate: 10%; at least 1.5-fold (0.19 log units) between middle value and limit.
By their numbers in this assay, from the lowest: compounds 3, 1 and 2 (each within the scatter of the next). At a limit, above all of these: compound 4.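

In this assay compound 4 gives > 25000 nM, which is a limit of the assay and not a number. Replacing hydroxy with isopropyl on this aromatic carbon, para to a large group, gives an at least 1.2-fold higher number from compound 2 to compound 4 (0.08 log units; that floor lies within the scatter), so the change brings no visible gain in inhibition, while the floor of the step is too small to establish a loss. Unlike the earlier step from methoxy to hydrogen, this change alters the group at this position itself, removing a hydrogen-bond donor and acceptor and leaving carbon only, yet the reading can go no further than this: the limit of > 25000 nM in this assay, at which 1 of the 4 values shown sits.

Going by these compounds, how far compound 4 truly lies past its limit remains open. Also open, on these data alone, is whether an amine or a carboxylic acid on this aromatic carbon would bring the number below that of compound 2.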